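Furan-3-yl gives way to 1-benzofuran-2-yl

The source may report more compounds than this note shows. Statements on the series, on what has been measured and on what is new or still open speak of the compounds shown alone.

Compound 1 `CNc1ncnc2c1c(-c1ccccc1)cn2[C@@H]1O[C@H](CO)[C@@H](O)[C@H]1O`: > 20000 nM (a limit)
Compound 2 `Nc1nc2c(c(-c3ccoc3)cn2[C@@H]2O[C@H](CO)[C@@H](O)[C@H]2O)c(=O)[nH]1`: 19600 nM

For the measured compounds named here, in a functional assay on K562 cells (Homo sapiens), read by MTT assay, with a stated time of 72 h (on this read-out lower numbers stand for stronger inhibition and higher numbers for weaker inhibition), compound 2 gives 19600 nM, the only actual number so far. Compound 1 reads > 20000 nM, which is a limit of the assay and not a number. Compound 3 `Nc1nc2c(c(-c3cc4ccccc4o3)cn2[C@@H]2O[C@H](CO)[C@@H](O)[C@H]2O)c(=O)[nH]1` carries 1-benzofuran-2-yl in place of furan-3-yl on an aromatic carbon. Going by the values given here, no measured step bears on this change, so in this assay only a small shift towards stronger inhibition is expected, probably within the scatter. The expected change is a 1.6-fold lower number from compound 2 to compound 3 (0.21 log units; within the scatter). For compound 3 the estimated value is 12000 nM, with an expected range from 3000 nM to 20000 nM.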

Compound 3, half-maximal inhibitory concentration: > 20000 nM
Compound 3 was reported as a limit; the forecaster's own chance of this, stated with the estimate: 50%; at least 1.6-fold (0.22 log units) between middle value and limit.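

In this assay, 1-benzofuran-2-yl in place of furan-3-yl on this aromatic carbon gives an at least 1.0-fold higher number from compound 2 to compound 3 (0.00 log units; that floor lies within the scatter). Compound 3 reads > 20000 nM, which is a limit of the assay and not a number. Going by these compounds, the added six-membered aromatic ring thus brings no sign of stronger inhibition, and the true size of the step stays unknown because the reading stops at the limit: the limit of > 20000 nM in this assay, at which 2 of the 3 values shown sit.

On these data alone, it remains open whether any group on this carbon can lower the number in this assay, for instance an amine or a carboxylic acid on the furan-3-yl ring.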